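This account rests on a few compounds, and the source may have more. Where it says the series, first, only, none or still open, it means among the compounds named here.

Measured in an ADME assay (liver) for metabolic stability, with Liver microsome (Homo sapiens) as the target, using microsomes and NADPH, with a stated time of 30 min, tested at 1 uM; on this read-out higher numbers stand for fast clearance and lower numbers for slow clearance:

- compound 1 `Nc1ccc(S(=O)(=O)N2CCN(c3ncc(C(O)(C(F)(F)F)C(F)(F)F)cc3C#CCO)CC2)cn1`: < 14 mL.min-1.g-1
- compound 2 `CS(=O)(=O)Nc1cccc(-c2cc(C(O)(C(F)(F)F)C(F)(F)F)cnc2N2CCN(S(=O)(=O)c3ccc(N)nc3)CC2)c1`: 40 mL.min-1.g-1
- compound 3 `Nc1ccc(S(=O)(=O)N2CCN(c3ncc(C(O)(C(F)(F)F)C(F)(F)F)cc3-c3cncc(F)c3)CC2)cn1`: 24 mL.min-1.g-1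

Compound 1 has the entry < 14 mL.min-1.g-1, which is a limit of the assay and not a number. Compound 3 gives 24 mL.min-1.g-1 and is not clearly separated from either neighbour: the measured gap is a 1.7-fold lower number from compound 2 to compound 3 (0.22 log units; within the scatter), and the floor on the other side is an at least 1.7-fold higher number from compound 1 to compound 3 (0.23 log units; that floor lies within the scatter).

Compound 4 `COc1cncc(-c2cc(C(O)(C(F)(F)F)C(F)(F)F)cnc2N2CCN(S(=O)(=O)c3ccc(N)nc3)CC2)c1` changes one small group on compound 3: methoxy in place of fluoro on an aromatic carbon. Among the measured compounds shown here, no measured step makes this exact swap. The closest evidence comes from larger changes at the same place on the shared core. Only an at least 2.8-fold higher number from compound 1 to compound 2 (0.45 log units; beyond the scatter) clears the scatter, while exchanging the whole aryl group in a 1.7-fold lower number from compound 2 to compound 3 (0.22 log units; within the scatter) does not. A much smaller edit is therefore expected to give no step beyond the scatter, with perhaps a slight upward drift.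

The expected step is a 1.2-fold higher number from compound 3 to compound 4 (0.07 log units; within the scatter). For compound 4 the estimated value is 28 mL.min-1.g-1, within an expected range of 15 mL.min-1.g-1 to 50 mL.min-1.g-1.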

Compound 4, intrinsic clearance in microsomes: 44 mL.min-1.g-1
The estimate for compound 4 lay 1.6-fold (0.20 log units) below the measured number; the measured number falls inside the stated range.
By their numbers in this assay, from the lowest: compounds 3, 2 and 4 (each within the scatter of the next). At a limit, below all of these: compound 1.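

In this assay, putting methoxy in place of fluoro on this pyridine ring gives a 1.8-fold higher number from compound 3 to compound 4 (0.26 log units; within the scatter), so the only direct test of a small edit at this carbon shows no clear shift. Exchanging the whole aryl group gives a 1.1-fold higher number from compound 2 to compound 4 (0.04 log units; within the scatter), so 5-methoxypyridin-3-yl and 3-(methanesulfonamido)phenyl cannot be told apart on this read-out. The one new step beyond the scatter is an at least 3.1-fold higher number from compound 1 to compound 4 (0.49 log units; beyond the scatter), the second after the step to compound 2, while the floor for compound 3 stays within the scatter, and the size of all these steps rests on the entry for compound 1, which is a limit: the limit of < 14 mL.min-1.g-1 in this assay, at which 1 of the 4 values shown sits.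

From the compounds shown here alone, whether a nitrile, an amine or a longer chain such as ethoxy at this carbon would clear the scatter stays open. So does the actual number for compound 1.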